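A Chlorophenyl Swap Tested on a Second Core

The source may report more compounds than this note shows. Statements on the series, on what has been measured and on what is new or still open speak of the compounds shown alone.

Compound 1 `O=c1[nH]cc(S(=O)(=O)Nc2ccccc2-c2cn(-c3ccc(F)cc3)nn2)c(=O)[nH]1` carries a 4-fluorophenyl group on a ring nitrogen. In a functional assay on OVCAR-3 cells (Homo sapiens) for antiproliferative activity, read by MTT assay, with a stated time of 24 h (on this read-out higher numbers stand for weaker inhibition and lower numbers for stronger inhibition), compound 1 gives > 20000 nM, which is a limit of the assay and not a number. Compound 2 `O=c1[nH]cc(S(=O)(=O)Nc2ccccc2-c2cn(-c3ccccc3Cl)nn2)c(=O)[nH]1` differs from it only by 2-chlorophenyl in place of 4-fluorophenyl on an aromatic nitrogen. In this assay compound 2 gives 3170 nM. That single change produced an at least 6.3-fold lower number from compound 1 to compound 2 (0.79 log units; beyond the scatter). Compound 3 `O=c1[nH]cc(S(=O)(=O)Nc2ccc(-c3cn(-c4ccc(F)cc4)nn3)cc2)c(=O)[nH]1` is built from the same atoms as compound 1, joined differently; how the two cores differ is not broken down here. In this assay compound 3 gives > 20000 nM, again a limit rather than a number. Compound 4 `O=c1[nH]cc(S(=O)(=O)Nc2ccc(-c3cn(-c4ccccc4Cl)nn3)cc2)c(=O)[nH]1`, not yet measured, differs from compound 3 by 2-chlorophenyl in place of 4-fluorophenyl on an aromatic nitrogen, the same change at the same place as the one already seen. Beside the earlier step of an at least 6.3-fold lower number from compound 1 to compound 2 (0.79 log units; beyond the scatter), the step expected here is an at least 2.5-fold lower number from compound 3 to compound 4 (0.39 log units; beyond the scatter), judged more cautiously since compound 3 starts from a limit of > 20000 nM in this assay, at which 2 of the 3 values shown sit, and the second core has no measured number to anchor it. Compound 4 is therefore estimated at 8000 nM, expected to lie between 2500 nM and 20000 nM.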

Compound 4, half-maximal inhibitory concentration: 4270 nM
Compound 4: the middle estimate sits 1.9-fold (0.27 log units) above what was measured; the measured number falls inside the stated range.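

In this assay the swap to 2-chlorophenyl on the aromatic nitrogen also lowers the number on the second core, with an at least 4.6-fold lower number from compound 3 to compound 4 (0.67 log units; beyond the scatter), so on both cores shown the change goes with stronger inhibition. The two steps can be set side by side, but their sizes cannot be ranked: the same change on two cores in this assay, an at least 6.3-fold lower number (0.79 log units; beyond the scatter) from compound 1 to compound 2 and an at least 4.6-fold lower number (0.67 log units; beyond the scatter) from compound 3 to compound 4; the limit leaves it open whether they differ. Compound 1 and compound 3 each start from a limit of the assay and not a number, so each step gives only a minimum size, and two cores are too few to make this a rule for the whole series: the limit of > 20000 nM in this assay, at which 2 of the 4 values shown sit.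

Each pair changes the halogen and its place on the phenyl ring together, and the compounds shown do not separate these two parts of the swap. They also leave open how a phenyl ring carrying an amine or a carboxylic acid in place of the halogen would read in this assay.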